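Stereocentre on the chain: from R to S

The source may report more compounds than this note shows. Statements on the series, on what has been measured and on what is new or still open speak of the compounds shown alone.

Measured in a functional assay (blood) for inhibition, with Homo sapiens as the target (on this read-out higher numbers stand for weaker inhibition and lower numbers for stronger inhibition), so far
- compound 1 `CC(COc1ccc2c(c1)c(SC(C)(C)C)c(CC(C)(C)C(=O)O)n2Cc1ccc(Cl)cc1)c1ccccn1` gives 270 nM
- compound 2 `C[C@@H](COc1ccc2c(c1)c(SC(C)(C)C)c(CC(C)(C)C(=O)O)n2Cc1ccc(Cl)cc1)c1ccccn1` gives 280 nM

Compound 2 stands level with compound 1 within the scatter in this assay and has no other neighbour. Compound 3 `C[C@H](COc1ccc2c(c1)c(SC(C)(C)C)c(CC(C)(C)C(=O)O)n2Cc1ccc(Cl)cc1)c1ccccn1` is its mirror partner at one centre, with the two compounds have the same atoms and bonds and differ only in configuration as drawn: 1 of 1 stereo elements differ; a stereocentre at a saturated chain carbon is drawn R in compound 2 and S in compound 3 as the whole difference. Going by the values given here, the one measured step bearing on this is a 1.0-fold higher number from compound 1 to compound 2 (0.02 log units; within the scatter) and it concerns the fact that one of compounds 1 and 2 is drawn with a defined configuration and the other without, at the place where they differ at the same stereocentre. A step of that size gives no ground for expecting a change beyond the scatter in either direction. The expected step is a 1.1-fold lower number from compound 2 to compound 3 (0.03 log units; within the scatter) and so stays within the scatter. Compound 3 is estimated at 260 nM with an expected range of 130 nM to 520 nM for now.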

Compound 3, half-maximal inhibitory concentration: 470 nM
Estimate against measurement, compound 3: 1.8-fold (0.26 log units) below; low and high end bracket the measured number.
By their numbers in this assay, from the lowest: compounds 1, 2 and 3 (each within the scatter of the next).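

Inverting the chain stereocentre from R to S gives, in this assay, a 1.7-fold higher number from compound 2 to compound 3 (0.22 log units; within the scatter). Going by these compounds alone, this is the first direct comparison of the two drawn configurations, and it does not separate them at this position. Against the compound drawn without a configuration, the S form gives a 1.7-fold higher number from compound 1 to compound 3 (0.24 log units; within the scatter), so all three compounds remain within the scatter of their neighbours.

Going by these compounds, whether an ethyl group on this stereocentre would separate the R and S forms remains open. The compounds shown also leave open whether this insensitivity to configuration holds with a different group on the shared core.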